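What one added methyl might do to compound 1

The source may report more compounds than this note shows. Statements on the series, on what has been measured and on what is new or still open speak of the compounds shown alone.

- compound 1 `S=c1n(-c2ccc(Cl)cc2)c(=S)n2n1CCCC2` gives 43.7 nM
- compound 2 `S=c1n(-c2ccccc2)c(=S)n2n1CCCC2` gives 6310 nM
- compound 3 `Cc1cc(Cl)ccc1-n1c(=S)n2n(c1=S)CCCC2` has not yet been measured

Among the compounds with values here, in a functional assay on the whole organism with Scenedesmus acutus as the target, read by spectrophotometry (on this read-out lower numbers stand for stronger inhibition and higher numbers for weaker inhibition), compound 1 gives 43.7 nM and holds the lower of the two numbers so far. The change leading to compound 3 is methyl in place of hydrogen on an aromatic carbon and it falls ortho to a large group and meta to the chloro group. Within the data shown here, only one measured step concerns this aromatic ring: a 140-fold higher number from compound 1 to compound 2 (2.16 log units; beyond the scatter) when hydrogen replaces chloro. Among the measured compounds shown here, that step is large, but compound 3 keeps its chloro group, and no measured pair shows what a methyl does. A smaller step is therefore expected, probably towards a higher number, though with real uncertainty in both directions. The expected change is a 2.3-fold higher number from compound 1 to compound 3 (0.36 log units; beyond the scatter) and this remains only an estimate. For compound 3 the estimated value is 100 nM with an expected range from 15 nM to 700 nM.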

Compound 3, half-maximal inhibitory concentration: 85.1 nM
Compound 3: the middle estimate sits 1.2-fold (0.07 log units) above what was measured; the range from low to high includes it.
By their numbers in this assay, from the lowest: compounds 1 and 3 (each within the scatter of the next); then compound 2.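

In this assay, methyl in place of hydrogen on an aromatic carbon gives a 1.9-fold higher number from compound 1 to compound 3 (0.29 log units; within the scatter), so this first measured change at the position ortho to a large group and meta to the chloro group cannot be told apart from the scatter of repeated measurements. The earlier step, a 140-fold higher number from compound 1 to compound 2 (2.16 log units; beyond the scatter), showed only what removing the chloro group does, whereas this result shows that a methyl can sit on the same ring, with the chloro group kept, and leave the number within that scatter. Nothing available explains this outcome.

The compounds shown leave open whether an ethyl group, a methoxy group or a carboxylic acid at this position would behave like methyl. They also leave open what a methyl would do on the ring of compound 2, which has no chloro group.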